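This account rests on a few compounds, and the source may have more. Where it says the series, first, only, none or still open, it means among the compounds named here.

In a physicochemical assay for solubility, in phosphate buffer, measured as kinetic solubility, with a stated time of 24 h, at pH 6.5 (a lower number here means a less soluble compound, a higher number a more soluble compound), compound 1 (`CCS(=O)(=O)c1ccc(Oc2cc(O[C@@H](C)CO)cc(-c3nccc(=O)[nH]3)c2)cc1`) gives 390000 nM and compound 2 (`CN(C)C(=O)c1ncc(Oc2cc(OC3CCCC3)cc(-c3nccc(=O)[nH]3)c2)cn1`) gives 398000 nM, so these two values lie within the usual scatter of each other. Compound 3 (`COC[C@H](C)Oc1cc(Oc2cnc(C(=O)N(C)C)nc2)cc(-c2nccc(=O)[nH]2)c1`) keeps the rest of compound 2 but carries 1-(methoxymethyl)ethyl in place of cyclopentyl on an oxygen on an aromatic ring. Within the data shown here, no measured pair of compounds shows what such a swap does, so the expected step, a 1.0-fold lower number from compound 2 to compound 3 (0.00 log units; within the scatter), is none beyond the scatter in this assay. For compound 3 the estimated value is 395000 nM, with an expected range of 230000 nM to 520000 nM.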

Compound 3, solubility: 342000 nM
Beside the measured number, compound 3's estimate is 1.2-fold (0.06 log units) above it; the range from low to high includes it.
By their numbers in this assay, from the lowest: compounds 3, 1 and 2 (each within the scatter of the next).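

Among these compounds, compound 2 and compound 3 form the first measured pair for this swap on an oxygen on an aromatic ring. In this assay, replacing cyclopentyl with 1-(methoxymethyl)ethyl gives a 1.2-fold lower number from compound 2 to compound 3 (0.07 log units; within the scatter). So, in this pair, an open chain with a hydrogen-bond acceptor and a defined stereocentre can stand in place of the ring without a step beyond the scatter. No measurement shown explains this result. Still open, going by these compounds, is whether an amine or a carboxylic acid on this oxygen would give a step beyond the scatter.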